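From Aryl Ether to Carboxylic Acid on the Shared Core

This account rests on a few compounds, and the source may have more. Where it says the series, first, only, none or still open, it means among the compounds named here.

Compound 1, `Cn1nc(COc2cccc(F)c2)c2c1CCN(C(=O)Nc1ccc(Cl)cc1)C2`: in an assay on cells for inhibition of Pendrin (Mus musculus), read by fluorescence, with a stated time of 10 min (a lower number here means a stronger inhibitor, a higher number a weaker inhibitor), compound 1 gives 6600 nM.
Compound 2, `CCOC(=O)c1nn(C)c2c1CN(C(=O)Nc1ccc(Cl)cc1)CC2`: in this assay compound 2 gives > 10000 nM, which is a limit of the assay and not a number.
Compound 3, `Cn1nc(C(=O)O)c2c1CCN(C(=O)Nc1ccc(Cl)cc1)C2`: not yet measured in this assay.

Within the data shown here, compound 1 is the only compound with an actual number in this assay; the one other value is a limit. Swapping its aryl ether for an ethyl ester gives compound 2, and that change brought an at least 1.5-fold higher number from compound 1 to compound 2 (0.18 log units; that floor lies within the scatter). The size of that step is only a floor, because of the limit of > 10000 nM in this assay, at which 1 of the 2 values shown sits; the true loss may be larger.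

Compound 3 makes a related change on the same aromatic carbon: carboxy in place of (3-fluorophenoxy)methyl on an aromatic carbon. A small polar acid now stands where compound 1 carried a larger aromatic ether. Among the measured compounds shown here, the one measured step of this kind, from compound 1 to compound 2, went toward weaker inhibition and likely hid part of its size behind the limit. The expectation is therefore a step toward a higher number, a 3.0-fold higher number from compound 1 to compound 3 (0.48 log units; beyond the scatter), with a real chance that compound 3 also returns only a limit. Compound 3 is estimated at 20000 nM, within a range of 6000 nM to 80000 nM.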

Compound 3, half-maximal inhibitory concentration: > 10000 nM
Compound 3 was reported as a limit; the forecaster's own chance of this, stated with the estimate: 70%; the middle value is on the limit's open side.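

In this assay, carboxy in place of (3-fluorophenoxy)methyl on this aromatic carbon gives an at least 1.5-fold higher number from compound 1 to compound 3 (0.18 log units; that floor lies within the scatter). This adds a second, quite different replacement: the ethoxycarbonyl of compound 2 and the much smaller carboxy of compound 3 both end at a limit of the assay rather than a number, so among the three compounds shown, only compound 1, with its (3-fluorophenoxy)methyl, gives a measured value here. Neither step away from compound 1 establishes a real loss of inhibition, as each is only a floor within the scatter, and the step from compound 2 to compound 3, hydrogen in place of ethyl on an oxygen next to a carbonyl group, cannot be read at all, for one shared reason: the limit of > 10000 nM in this assay, at which 2 of the 3 values shown sit.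

The compounds shown leave open which part of the (3-fluorophenoxy)methyl matters, a question that a plain phenoxymethyl without the fluorine or a methoxymethyl without the aromatic ring would address. They also leave open the true values of compound 2 and compound 3, and so whether the ester and the acid differ at all.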